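Moving the fluorine around the outer ring of a weak series

The compounds below may be only part of what the source reports. "The series", "measured", "known", "first", "only" and "open" are said of these compounds alone.

Measured so far:
compound 1 `Cc1cnc(Nc2ccc(F)cc2)nc1Nc1nc2ccccc2s1`: > 50000 nM
compound 2 `COc1ccc(Nc2ncc(C)c(Nc3nc4ccccc4s3)n2)cc1`: > 50000 nM
compound 3 `Cc1cnc(Nc2ccc(N3CCCCC3)cc2)nc1Nc1nc2ccccc2s1`: 37200 nM

In a functional assay on MDA-MB-231 cells (Homo sapiens) for antiproliferative activity, read by MTT assay, with a stated time of 48 h (on this read-out lower numbers stand for stronger inhibition and higher numbers for weaker inhibition), compound 2 gives only a limit, > 50000 nM, and not a number. Compound 1 likewise reaches only the limit (the limit of > 50000 nM in this assay, at which 2 of the 3 values shown sit). Compound 3 alone gives a number, 37200 nM. Compound 4 `Cc1cnc(Nc2cccc(F)c2)nc1Nc1nc2ccccc2s1` differs from compound 2 by 3-fluorophenyl in place of 4-methoxyphenyl on a nitrogen on an aromatic ring. The step that the two limits leave unreadable from compound 1 to compound 2 is unreadable, and the step of an at least 1.3-fold lower number from compound 2 to compound 3 (0.12 log units; that floor lies within the scatter) is small. Among the measured compounds shown here, no measured step swaps one fluorophenyl for another, so compound 4 is expected to stay near compound 2, most likely again only a limit, and the expected step is a step that the limit leaves unreadable from compound 2 to compound 4. Compound 4 is therefore estimated at 60000 nM, between 25000 nM and 150000 nM.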

Compound 4, half-maximal inhibitory concentration: > 50000 nM
Compound 4 gave a limit, no number; the forecaster's own chance of this, stated with the estimate: 75%; the middle value is on the limit's open side.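

Compound 4, like compound 1 and compound 2, gives only a limit, so no step between these three compounds can be read: the limit of > 50000 nM in this assay, at which 3 of the 4 values shown sit.

The compounds shown leave open whether 3-fluorophenyl and 4-fluorophenyl differ in activity at all.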